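Notes on a benzothiazole replacement in compound 1

The compounds below may be only part of what the source reports. "The series", "measured", "known", "first", "only" and "open" are said of these compounds alone.

- compound 1 `CCn1cc(-c2nc3ccccc3[nH]2)c(=O)c2cc(F)c(N3CCNCC3)nc21`: 2000 nM
- compound 2 `CCn1cc(-c2nc3ccccc3[nH]2)c(=O)c2cc(F)c(N3CCNC(C)C3)c(F)c21`: 19100 nM
- compound 3 `CCn1cc(-c2nc3ccccc3o2)c(=O)c2cc(F)c(N3CCN(C)CC3)cc21`: 87400 nM

All three values come from a functional assay on KB cells (Homo sapiens) for cytotoxicity, read by MTT assay, with a stated time of 48 h; a higher number here means a weaker inhibitor, a lower number a stronger inhibitor. Compound 1 has the lowest number, and its gaps to compound 2 and compound 3 both lie beyond the scatter. Compound 4 `CCn1cc(-c2nc3ccccc3s2)c(=O)c2cc(F)c(N3CCNCC3)nc21`, not yet measured, keeps the core of compound 1 with one change: 1,3-benzothiazol-2-yl in place of 1H-benzimidazol-2-yl on an aromatic carbon. Among the measured compounds shown here, no measured pair isolates this change. For the measured compounds named here, compound 3, the only measured compound without the 1H-benzimidazol-2-yl group, gives 87400 nM, but its core also differs, so it is a weak guide. A moderate move toward a higher number is expected, probably beyond the scatter. The expected step is a 3.5-fold higher number from compound 1 to compound 4 (0.54 log units; beyond the scatter). For compound 4 the estimated value is 7000 nM, with an expected range of 1500 nM to 35000 nM.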

Compound 4, half-maximal inhibitory concentration: 2400 nM
Compound 4: middle estimate off by 2.9-fold (0.46 log units), on the high side; measured number inside the range.
By their numbers in this assay, from the lowest: compounds 1 and 4 (each within the scatter of the next); then compound 2; then compound 3.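

Replacing 1H-benzimidazol-2-yl with 1,3-benzothiazol-2-yl on this aromatic carbon gives a 1.2-fold higher number from compound 1 to compound 4 (0.08 log units; within the scatter) in this assay. At this position on the core of compound 1, the hydrogen-bond donor of the 1H-benzimidazol-2-yl group is therefore not needed to keep the value, and the ring nitrogen can give way to sulfur. No measurement on hand explains this result. Still open, from the compounds shown here alone, is whether a carboxylic acid or a simple amine at this position would hold the value, and whether the same replacement behaves alike on the core of compound 2.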